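Swapping one halogen for another on the amino-bearing ring

This account rests on a few compounds, and the source may have more. Where it says the series, first, only, none or still open, it means among the compounds named here.

Of the compounds shown here, three sharing one core have been measured so far. Compound 1 `COc1ccc(-c2nn(-c3ccccc3)cc2CNc2ccc(C)cc2)cc1` gives 8160 nM in a functional assay on MCF7 cells (Homo sapiens) for antiproliferative activity, read by MTT assay, with a stated time of 48 h; a higher number here means a weaker inhibitor, a lower number a stronger inhibitor. Compound 2 `Clc1ccc(NCc2cn(-c3ccccc3)nc2-c2ccc(Cl)cc2)cc1` gives 2280 nM, and compound 3 `Clc1ccc(NCc2cn(-c3ccccc3)nc2-c2ccc(Br)cc2)cc1` gives 4150 nM. On these numbers compound 3 sits second highest of the three, with compound 2 nearest at a lower number and compound 1 furthest at a higher one, both differences falling within the scatter.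

Compound 4 `Fc1ccc(NCc2cn(-c3ccccc3)nc2-c2ccc(Br)cc2)cc1` differs from compound 3 in one place: fluoro in place of chloro on an aromatic carbon. Within the data shown here, the only measured step that speaks to a halogen swap is a 1.8-fold higher number from compound 2 to compound 3 (0.26 log units; within the scatter), where bromo replaced chloro on the other aromatic ring and the number barely moved. Among the measured compounds shown here, no step among the measured compounds touches the (4-chlorophenyl)amino part itself, so the evidence is thin and indirect.

Given that, compound 4 is expected to stay close to compound 3, with a step of a 1.1-fold higher number from compound 3 to compound 4 (0.04 log units; within the scatter) that is not expected to exceed the scatter. The estimate for compound 4 is 4500 nM, with a range from 1500 nM to 14000 nM.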

Compound 4, half-maximal inhibitory concentration: 3960 nM
The estimate for compound 4 lay 1.1-fold (0.06 log units) above the measured number; the range from low to high includes it.
By their numbers in this assay, from the lowest: compounds 2, 4, 3 and 1 (each within the scatter of the next, the first and the last beyond it).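

Among these compounds, this is the first measured step at the (4-chlorophenyl)amino part itself: in this assay, fluoro in place of chloro gives a 1.0-fold lower number from compound 3 to compound 4 (0.02 log units; within the scatter). The step lies within the scatter, so on the bromo-bearing background of compound 3 and compound 4, these two halogens cannot be told apart at this place, para to a large group. Nothing available here explains this result or shows how the compounds act on the cells.

The compounds shown leave open whether a group of a different kind at this place, such as an amine, a carboxylic acid or a nitrile, would shift the number beyond the scatter. They also leave open whether the fluoro-for-chloro swap would read the same with chloro rather than bromo on the other ring.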